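The source may hold more compounds than are shown below. What is called first, only, known or untested is meant among the compounds shown, and "the series" means these compounds.

Compound 1 `CC(C)Cn1cc(-c2ccnc3[nH]c(C4CCN(CC(=O)N(C)C)CC4)cc23)ccc1=O` and compound 2 `CCn1cc(-c2ccnc3[nH]c(C4CCN(CC(=O)N(C)C)CC4)cc23)ccc1=O` share one core and differ only by methyl in place of isopropyl on a saturated chain carbon bound to an aromatic nitrogen. In an ADME assay on microsomes from liver (Homo sapiens) for metabolic stability (on this read-out higher numbers stand for fast clearance and lower numbers for slow clearance), compound 1 gives 21 uL/min. Compound 2 reaches the limit of this assay and is reported only as < 3 uL/min, so no number is known for it, just a bound. The step is an at least 7.0-fold lower number from compound 1 to compound 2 (0.84 log units; beyond the scatter), and that its end point is a bound rather than a value is marked by the limit of < 3 uL/min in this assay, at which 1 of the 2 values shown sits. Among the measured compounds shown here, compound 3 `CN(C)C(=O)CN1CCC(c2cc3c(-c4ccc(=O)n(C)c4)ccnc3[nH]2)CC1` has not been run in this assay; it differs from compound 2 by hydrogen in place of methyl on a saturated chain carbon bound to an aromatic nitrogen, a change of the same kind as the one from compound 1 to compound 2, read as ethyl to methyl. That earlier step ran toward slower clearance, and nothing measured suggests a turn back, so the step that the limit leaves unreadable from compound 2 to compound 3 is expected to be small, with compound 3 expected to remain near the bound. Compound 3 is therefore estimated at 2 uL/min in this assay, between 1 uL/min and 5 uL/min, and most likely returned again as a limit.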

Compound 3, intrinsic clearance in a liver preparation (reported as CLH), per the amount of preparation that the assay uses: < 3 uL/min
Compound 3 was reported as a limit (the forecaster's own chance of this, stated with the estimate: 70%); the middle value does not contradict the limit.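

In this assay compound 3 is again a limit, < 3 uL/min, so a second trimming at this place, on a saturated chain carbon bound to an aromatic nitrogen, still yields no number. The step from compound 2 to compound 3 cannot be read, since both of its ends are limits, and hydrogen in place of methyl therefore has no measurable size in these data. What the new result adds is that the low end of the read-out holds for two of the three substituents, not for one alone, and the only readable comparison with the isopropyl end of the series is an at least 7.0-fold lower number from compound 1 to compound 3 (0.84 log units; beyond the scatter), a size set by the floor of the assay and not by compound 3 itself: the limit of < 3 uL/min in this assay, at which 2 of the 3 values shown sit.

As far as these compounds go, whether compound 2 and compound 3 truly differ in clearance stays open, as does the point along the chain at which clearance starts to rise from the limit towards the value of compound 1. Also open, from the compounds shown here alone, is how a longer straight chain, or a chain ending in an amine or a carboxylic acid, would read at this place in this assay.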